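The source may report more compounds than this note shows. Statements on the series, on what has been measured and on what is new or still open speak of the compounds shown alone.

Among the three measured compounds, compound 1 `CCCC(=O)N1CC2CC(C1)N2` stands highest in an assay on CHO cells for agonist activity at Neuronal acetylcholine receptor; alpha3/alpha6/beta2/beta3 (Homo sapiens), read by FLIPR and calcium flux (on this read-out higher numbers stand for larger maximal responses and lower numbers for smaller maximal responses), where compound 1 gives 92%. Compound 2 `CC(C)C(=O)N1CC2CC(C1)N2` gives 45% and compound 3 `C[C@H]1C[C@H]1C(=O)N1CC2CC(C1)N2` gives 60%; the corresponding steps are a number 47 percentage points lower from compound 1 to compound 2 (beyond the scatter) and a number 32 percentage points lower from compound 1 to compound 3 (beyond the scatter), with a number 15 percentage points higher from compound 2 to compound 3 (beyond the scatter) between them. Compound 4 `C[C@@H]1C[C@H]1C(=O)N1CC2CC(C1)N2` differs from compound 1 by 2-methylcyclopropyl in place of propyl on a carbonyl carbon and is the other stereoisomer of compound 3 at the 2-methylcyclopropyl group. The step from compound 1 to compound 3 bears most directly on it, and the step from compound 1 to compound 2 points the same way, so a large fall in this assay is expected: a number 32 percentage points lower from compound 1 to compound 4 (beyond the scatter). Compound 4 is therefore estimated at 60%, between 40% and 80%.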

Compound 4, largest response reached (Emax), in percent of the reference or control that the assay uses: 110%
Compound 4: the middle estimate sits 50 percentage points below what was measured, outside the stated range (above it).
By their numbers in this assay, from the lowest: compound 2; then compound 3; then compound 1; then compound 4.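

In this assay the 2-methylcyclopropyl group does not in itself bring a fall: the response depends on its stereo arrangement, with a number 50 percentage points higher from compound 3 to compound 4 (beyond the scatter) at a single stereocentre on a saturated ring carbon. The same group also gives a number 18 percentage points higher from compound 1 to compound 4 (beyond the scatter) and a number 65 percentage points higher from compound 2 to compound 4 (beyond the scatter), so a ring on the carbonyl carbon can match or exceed the propyl chain, although compound 3 stays lower. The stereo comparison carries one caution: the fact that one of compounds 3 and 4 is drawn with a defined configuration and the other without, at the place where they differ

The compounds shown leave open how an unsubstituted cyclopropyl or a longer chain such as butyl would behave at this position.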